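The source may hold more compounds than are shown below. What is called first, only, known or untested is meant among the compounds shown, and "the series" means these compounds.

The series shares the core of compound 1 `COC(=O)C[C@H](NC(=O)OC(C)(C)C)C(=O)N(C)C1(C(=O)NCc2ccccc2)CCN(Cc2ccccc2)CC1`, which in an ADME assay on MDCK cells (Canis lupus familiaris) for cytotoxicity, read by microscopy, with a stated time of 72 h (a lower number here means that less compound is tolerated, a higher number that more compound is tolerated), gives 20000 nM. Compound 2 `CCC(C)N(C(=O)[C@H](CC(=O)OC)NC(=O)OC(C)(C)C)C1(C(=O)NCc2ccccc2)CCN(Cc2ccccc2)CC1` carries sec-butyl in place of methyl on an amide-type nitrogen and in this assay gives 84000 nM. Compound 3 `COC(=O)C[C@H](NC(=O)OC(C)(C)C)C(=O)N(Cc1ccc(C(F)(F)F)cc1)C1(C(=O)NCc2ccccc2)CCN(Cc2ccccc2)CC1` carries 4-(trifluoromethyl)benzyl on that nitrogen and in this assay gives 84000 nM. Compound 3 thus stands level with compound 2 at the digits shown, the two together giving the highest numbers of the three. The step of a 4.2-fold higher number from compound 1 to compound 3 (0.62 log units; beyond the scatter) is modest, as is a 4.2-fold higher number from compound 1 to compound 2 (0.62 log units; beyond the scatter), while no change at the digits printed from compound 2 to compound 3 (within the scatter).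

Compound 4 `COC(=O)C[C@H](NC(=O)OC(C)(C)C)C(=O)N(Cc1ccc(Cl)cc1)C1(C(=O)NCc2ccccc2)CCN(Cc2ccccc2)CC1` differs from compound 3 by chloro in place of trifluoromethyl on an aromatic carbon. Within the data shown here, no measured step alters a substituent on this aromatic ring; the steps seen so far all exchange the whole group on the amide-type nitrogen, and even there the exchange of sec-butyl for 4-(trifluoromethyl)benzyl left the number unchanged, with only the two enlargements from methyl raising it modestly. The change from compound 3 to compound 4 sits at a place the measured steps do not touch, so nothing here argues for a move in either direction. The expectation for compound 4 is therefore a step of no change at the digits printed from compound 3 to compound 4 (within the scatter), within the scatter. Compound 4 is estimated at 84000 nM, with a range from 30000 nM to 200000 nM.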

Compound 4, minimum cytotoxic concentration: 100000 nM
Beside the measured number, compound 4's estimate is 1.2-fold (0.08 log units) below it, and the stated range covers the measured number.
By their numbers in this assay, from the lowest: compound 1; then compounds 2, 3 and 4 (each within the scatter of the next).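

In this assay, among these compounds, the position on an aromatic carbon of a six-membered aromatic ring of carbon only, para to a large group, is changed directly for the first time: chloro, 1 heavy atom, in place of trifluoromethyl, 4 heavy atoms, gives a 1.2-fold higher number from compound 3 to compound 4 (0.08 log units; within the scatter) and so stays within the scatter despite the smaller group. With 4-chlorobenzyl on the amide-type nitrogen, the comparison with sec-butyl reads a 1.2-fold higher number from compound 2 to compound 4 (0.08 log units; within the scatter) while the comparison with methyl reads a 5.0-fold higher number from compound 1 to compound 4 (0.70 log units; beyond the scatter), so compound 4 joins compound 2 and compound 3 in a group that lies within the scatter and sets only compound 1 apart. Nothing measured here bears on why the number holds across this exchange.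

From the compounds shown here alone, whether an amine or a carboxylic acid in place of chloro on this aromatic carbon would keep the number in the same range remains open, as does the result of plain hydrogen there. Going by these compounds, a longer chain than sec-butyl on the amide-type nitrogen is also open, so the reach of the shift seen from methyl has no defined limit yet.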